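Ester chain length in a fluorinated chromone series

This account rests on a few compounds, and the source may have more. Where it says the series, first, only, none or still open, it means among the compounds named here.

Three compounds share a core and differ at one saturated chain carbon bound to an aromatic carbon. Compound 1 `Cc1c(F)c(N)c2c(=O)cc(-c3ccc(N)c(F)c3)oc2c1F` carries hydrogen there; compound 2 `CCCCc1c(F)c(N)c2c(=O)cc(-c3ccc(N)c(F)c3)oc2c1F` carries propyl instead, the change being (propyl in place of hydrogen on a saturated chain carbon bound to an aromatic carbon). In a functional assay on HeLa cells (Homo sapiens) for cytotoxicity, read by neutral red uptake, with a stated time of 3 days (a higher number here means a weaker inhibitor, a lower number a stronger inhibitor), compound 1 gives only a limit, > 100000 nM. Compound 2 likewise gives only a limit in this assay, > 100000 nM. The step that the two limits leave unreadable from compound 1 to compound 2 therefore cannot be sized, because the limit of > 100000 nM in this assay, at which 2 of the 3 values shown sit, caps both values. Compound 3 `CCC(=O)OCc1c(F)c(N)c2c(=O)cc(-c3ccc(N)c(F)c3)oc2c1F` differs from compound 1 by propanoyloxy in place of hydrogen on a saturated chain carbon bound to an aromatic carbon, and in this assay compound 3 gives 69000 nM, a step of an at least 1.4-fold lower number from compound 1 to compound 3 (0.16 log units; that floor lies within the scatter) and, against compound 2, of an at least 1.4-fold lower number from compound 2 to compound 3 (0.16 log units; that floor lies within the scatter).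

Compound 4 `CCCCCC(=O)OCc1c(F)c(N)c2c(=O)cc(-c3ccc(N)c(F)c3)oc2c1F` differs from compound 3 by propyl in place of hydrogen on a saturated chain carbon, two bonds along the chain from a carbonyl carbon. This is the same kind of change as that from compound 1 to compound 2, though the place differs: there the chain carbon is bound to an aromatic carbon, here it lies two bonds along the chain from a carbonyl carbon. Since that earlier step was unreadable, the expectation rests on compound 3 alone. Compound 4 is expected to show a step of a 1.1-fold lower number from compound 3 to compound 4 (0.03 log units; within the scatter) in this assay. Compound 4 is thus estimated at 65000 nM, between 20000 nM and 150000 nM.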

Compound 4, half-maximal inhibitory concentration: 34000 nM
Beside the measured number, compound 4's estimate is 1.9-fold (0.28 log units) above it; measured number inside the range.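

In this assay, propyl in place of hydrogen on a saturated chain carbon, two bonds along the chain from a carbonyl carbon, gives a 2.0-fold lower number from compound 3 to compound 4 (0.31 log units; beyond the scatter), and the ester chain of compound 4 also sets it apart from the two compounds without an ester, with an at least 2.9-fold lower number from compound 2 to compound 4 (0.46 log units; beyond the scatter) and an at least 2.9-fold lower number from compound 1 to compound 4 (0.46 log units; beyond the scatter). The same exchange on a saturated chain carbon bound to an aromatic carbon cannot be read, and neither can any other step between the two capped values, because both sit at a limit: the limit of > 100000 nM in this assay, at which 2 of the 4 values shown sit. The change therefore has one readable instance, a single pair on a single core, and this shows nothing about whether its size would carry over to another place or another core.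

Going by these compounds, it remains open whether a longer chain than pentylcarbonyl would lower the number further, or whether an amine or a carboxylic acid in place of the propyl would keep the step. Also open, on these data alone, is how these ester chains behave on a different core.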